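Swapping the octanoyl chain for a chlorobenzoyl group

The source may report more compounds than this note shows. Statements on the series, on what has been measured and on what is new or still open speak of the compounds shown alone.

Measured compounds:
Compound 1, `CCCCCCCCC(=O)N1c2ccccc2CCC1C(=O)Nc1ccccc1C(F)(F)F`: 6180 nM
Compound 2, `O=C(Nc1ccc(O)cc1)C1CCc2ccccc2N1`: > 100000 nM
Compound 3, `CCCCCCCCC(=O)N1c2ccccc2CCC1C(=O)Nc1cc(C(F)(F)F)cc(C(F)(F)F)c1`: 2230 nM

In a functional assay on NUGC-3 cells (Homo sapiens) for cytotoxicity, read by sulforhodamine B assay, with a stated time of 72 h (a lower number here means a stronger inhibitor of growth, a higher number a weaker inhibitor of growth), compound 1 gives 6180 nM, the higher of the two numbers recorded. Compound 3 gives 2230 nM, a lower number that lies beyond the scatter. For compound 2 only a limit is recorded, > 100000 nM, at the limit of > 100000 nM in this assay, at which 1 of the 3 values shown sits, so it is not a number and says only that growth inhibition was not reached within the range tested.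

Compound 4, `O=C(Nc1ccccc1C(F)(F)F)C1CCc2ccccc2N1C(=O)c1ccc(Cl)cc1`, is compound 1 with 4-chlorophenyl in place of octyl on a carbonyl carbon. For the measured compounds named here, no pair of measured compounds differs in just this place, so no measured step shows what such a change does in this assay. The core, the amide and the trifluoromethyl-bearing aniline are kept unchanged, and the acyl group is replaced by one of similar size. The step from compound 1 to compound 4 is therefore expected to be small, a 1.3-fold higher number from compound 1 to compound 4 (0.11 log units; within the scatter), possibly none beyond the scatter. Compound 4 is estimated at 8000 nM, within 2000 nM to 32000 nM.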

Compound 4, concentration for 50% growth inhibition: 551 nM
The estimate for compound 4 lay 15-fold (1.16 log units) above the measured number, and the stated range ends above it.
By their numbers in this assay, from the lowest: compound 4; then compound 3; then compound 1. At a limit, above all of these: compound 2.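

In this assay, the group on the carbonyl carbon bonded to the amide-type nitrogen in a ring proves to be a strong lever: 4-chlorophenyl in place of octyl gives an 11-fold lower number from compound 1 to compound 4 (1.05 log units; beyond the scatter). Compound 1 and compound 3 both carry octyl here, so this is the only step shown that varies this place, and it shows that the number responds to what sits there. No measured property among the data bears on this step, so it stands without an explanation.

From the compounds shown here alone, a single step cannot separate the ring from the chlorine on it, so a plain phenyl, a 4-methoxyphenyl or a shorter chain such as butyl at this place remains open. Also open, going by these compounds, is whether 4-chlorophenyl would give a similar step on compound 3, with its two trifluoromethyl groups.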